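The source may hold more compounds than are shown below. What is called first, only, known or untested is meant among the compounds shown, and "the series" means these compounds.

Compounds measured in an assay on microsomes for inhibition of acyl-CoA:cholesterol acyltransferase (Oryctolagus cuniculus); on this read-out lower numbers stand for stronger inhibition and higher numbers for weaker inhibition:
compound 1 `Cc1ccccc1C1(CNC(=O)Nc2c(C(C)C)cccc2C(C)C)CCCC1` gives 17 nM;
compound 2 `CC(C)c1ccc(C2(CNC(=O)Nc3c(C(C)C)cccc3C(C)C)CCCC2)cc1` gives 48 nM.

For the measured compounds named here, compound 2 has the higher of the two numbers, with compound 1 as its only neighbour. Going by the values given here, the single measured step, a 2.8-fold higher number from compound 1 to compound 2 (0.45 log units; beyond the scatter), replaced one aryl group with another on the saturated ring carbon and thus shows that what sits on that aryl ring moves this assay by a modest amount.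

Compound 3 `CC(C)c1cccc(C(C)C)c1NC(=O)NCC1(c2ccc(Cl)cc2)CCCC1` differs from compound 2 by chloro in place of isopropyl on an aromatic carbon. Among the compounds with values here, no measured step exchanges isopropyl for chloro at this position, so nothing directly bears on this change; the step from compound 1 to compound 2 only suggests that groups on this ring shift the number modestly rather than strongly.

For compound 3 a shift of a 1.2-fold lower number from compound 2 to compound 3 (0.08 log units; within the scatter) is therefore expected, which may not exceed the scatter. The expected value for compound 3 is 40 nM, within a range from 15 nM to 110 nM.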

Compound 3, half-maximal inhibitory concentration: 32 nM
For compound 3 the middle estimate is 1.3-fold (0.10 log units) above the measured one, and the stated range covers the measured number.
By their numbers in this assay, from the lowest: compounds 1, 3 and 2 (each within the scatter of the next, the first and the last beyond it).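

In this assay, the exchange of isopropyl for chloro on the aromatic carbon, which replaces a group of 3 heavy atoms with a single atom, gives a 1.5-fold lower number from compound 2 to compound 3 (0.18 log units; within the scatter) and so leaves no difference that can be told from the scatter. The 4-chlorophenyl group also stays close to the 2-methylphenyl group, with a 1.9-fold higher number from compound 1 to compound 3 (0.27 log units; within the scatter) as the step, so compound 3 cannot be ordered against either neighbour, even though compound 1 and compound 2 lie beyond the scatter of each other. No available evidence explains these small differences.

The compounds shown leave open whether a group of another kind at this place, such as an amine or a carboxylic acid, would move the number further. They also cannot separate the effect of the group from that of its place on the ring, since compound 1 differs from the others in both.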